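A Longer Chain at the Limit of Tolerance

This account rests on a few compounds, and the source may have more. Where it says the series, first, only, none or still open, it means among the compounds named here.

In an ADME assay on 2209-23 cells (Homo sapiens) for cytotoxicity, read by WST assay (a lower number here means that less compound is tolerated, a higher number that more compound is tolerated), compound 1 (`COc1cc(Cn2c(=O)c(C3=CS(=O)(=O)c4cc(NS(C)(=O)=O)ccc4N3)c(O)c3cc(F)ccc32)ccc1F`) gives > 50000 nM as a limit of the assay. Compound 2 (`CCCC(C)n1c(=O)c(C2=CS(=O)(=O)c3cc(NS(C)(=O)=O)ccc3N2)c(O)c2cc(F)ccc21`) gives > 50000 nM as a limit too, so it has no exact position. Compound 3 (`CC(C)(C)CCn1c(=O)c(C2=CS(=O)(=O)c3cc(NS(C)(=O)=O)ccc3N2)c(O)c2cc(F)ccc21`) carries 3,3-dimethylbutyl in place of 1-methylbutyl on an aromatic nitrogen. Among the measured compounds shown here, the one measured change on that nitrogen is a step that the two limits leave unreadable from compound 1 to compound 2 and the record so far is the limit of > 50000 nM in this assay, at which 2 of the 2 values shown sit, with no readable step size. In this assay no step beyond the scatter is therefore expected, and no direction can be foreseen. The estimated change is a step that the limit leaves unreadable from compound 2 to compound 3 at most modest. The expected value for compound 3 is 60000 nM within an estimated range from 30000 nM to 120000 nM and will probably be reported as a limit.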

Compound 3, half-maximal cytotoxic concentration: > 50000 nM
Compound 3: no number, only a limit (the forecaster's own chance of this, stated with the estimate: 85%); the middle value is on the limit's open side.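

In this assay compound 3 gives > 50000 nM, a limit of the assay. Among the compounds shown here, no step from compound 1 or compound 2 to compound 3 can be read. Going by these compounds, whether these three compounds differ in tolerated concentration remains open.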